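Methoxy to Hydroxy on the Benzylamide: Expected Cytotoxicity

The source may hold more compounds than are shown below. What is called first, only, known or untested is meant among the compounds shown, and "the series" means these compounds.

Compound 1 `CC(C)Cc1nn(-c2nccs2)cc1C(=O)NCc1ccccc1F` gives in a toxicity assay on HepG2 2.2.15 cells (Homo sapiens) for cytotoxicity, read by CCK-8 assay, with a stated time of 8 days (a lower number here means that less compound is tolerated, a higher number that more compound is tolerated), a value of > 100000 nM, which is a limit of the assay.
Compound 2 `COc1ccc(CNC(=O)c2cn(-c3nccs3)nc2CC(C)C)cc1` gives in this assay a value of > 100000 nM, which is a limit of the assay.

Compound 2 stands only at a limit in this assay, and so does compound 1; the step that the two limits leave unreadable from compound 1 to compound 2 therefore cannot be read, since the limit of > 100000 nM in this assay, at which 2 of the 2 values shown sit, holds for both values shown. Compound 3 `CC(C)Cc1nn(-c2nccs2)cc1C(=O)NCc1ccc(O)cc1` differs from compound 2 by hydrogen in place of methyl on an oxygen on an aromatic ring. Within the data shown here, no measured step bears on this change, and the one step between measured compounds is itself unreadable. With both neighbours at the limit, compound 3 is expected to show no step beyond the scatter, so a step that the limit leaves unreadable from compound 2 to compound 3 is the estimated change in this assay. For compound 3 the estimate in this assay is 150000 nM, within a range of 60000 nM to 400000 nM, most likely reported again as a limit.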

Compound 3, half-maximal cytotoxic concentration: > 100000 nM
Compound 3 ended at the assay's limit; the forecaster's own chance of this, stated with the estimate: 80%; the middle value is on the limit's open side.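

Compound 3 sits at a limit of the assay, as do compound 1 and compound 2, so no step among them can be read in this assay: the limit of > 100000 nM in this assay, at which 3 of the 3 values shown sit.

The compounds shown leave open what value any of the three would reach in this assay, and whether 2-fluorophenyl, 4-methoxyphenyl and 4-hydroxyphenyl differ there at all.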